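Replacing 2-benzamidoethyl with methoxycarbonyl on a shared core

The compounds below may be only part of what the source reports. "The series", "measured", "known", "first", "only" and "open" are said of these compounds alone.

In a functional assay on MDA-MB-435 cells (Homo sapiens) for cytotoxicity, read by MTT assay, with a stated time of 72 h (on this read-out lower numbers stand for stronger inhibition and higher numbers for weaker inhibition), compound 1 (`N[C@H]1CC[C@H](Nc2c(C(=O)NCc3ccc(F)cc3)nc(N3CCCCS3(=O)=O)c3cccnc23)CC1`) gives 5000 nM and compound 3 (`N[C@H]1CC[C@H](Nc2c(C(=O)NCc3cccc(C(F)(F)F)c3)nc(Br)c3cccnc23)CC1`) gives 4200 nM. These two values lie within the usual scatter of each other.

Compound 2 (`O=C(NCCCNc1c(C(=O)NCc2ccc(F)cc2)nc(Br)c2cccnc12)c1ccccc1`) reaches only a limit, > 20000 nM, and no number. Compound 2 therefore stands at the limit of > 20000 nM in this assay, at which 1 of the 3 values shown sits.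

Compound 4 (`COC(=O)CNc1c(C(=O)NCc2ccc(F)cc2)nc(Br)c2cccnc12`) keeps the core of compound 2 but has methoxycarbonyl in place of 2-benzamidoethyl on a saturated chain carbon bound to a nitrogen on an aromatic ring. Going by the values given here, no measured pair in this small set shows what such an exchange does in this assay, so no step beyond the scatter is expected in either direction. The expected step is a number no higher from compound 2 to compound 4 (the limit leaves the size open). A limit rather than a number is also a likely outcome for compound 4. Compound 4 is estimated at 20000 nM, with an expected range from 7000 nM to 50000 nM.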

Compound 4, half-maximal inhibitory concentration: 10000 nM
The estimate for compound 4 lay 2.0-fold (0.30 log units) above the measured number; the measured number falls inside the stated range.
By their numbers in this assay, from the lowest: compounds 3, 1 and 4 (each within the scatter of the next, the first and the last beyond it). At a limit, above all of these: compound 2.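

In this assay, going by these compounds alone, the exchange of 2-benzamidoethyl for methoxycarbonyl gives the first step at this place on the shared core, an at least 2.0-fold lower number from compound 2 to compound 4 (0.30 log units; that floor lies within the scatter), and that floor alone lies within the scatter. The entering group has no ring and fewer heavy atoms than the leaving one, yet it gives a measured number where the earlier compound on this core gave none. From the compounds shown here alone, the true size of the step remains unknown, as compound 2 stands only at a limit: the limit of > 20000 nM in this assay, at which 1 of the 4 values shown sits.

The compounds shown leave open whether a carboxylic acid in place of methoxycarbonyl would move the number in either direction. They also leave open what a primary amide or a longer chain ending in the same ester would do at this place.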